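One Acetoxy Exchanged: The Step to Compound 4

This account rests on a few compounds, and the source may have more. Where it says the series, first, only, none or still open, it means among the compounds named here.

Measured in a functional assay on A549 cells (Homo sapiens) for cytotoxicity, read by MTT assay; a lower number here means a stronger inhibitor, a higher number a weaker inhibitor:
- compound 1 `C=C1[C@H](OC(C)=O)C[C@H](OC(C)=O)[C@@]2(C)[C@@H](OC(C)=O)C[C@@H](OC(C)=O)[C@]3(CO3)[C@@H]2[C@H](OC(C)=O)[C@]2(O)[C@@H](C)C(=O)O[C@H]2[C@H]1Cl`: < 1500 nM
- compound 2 `C=C1[C@H](OC(C)=O)C[C@H](OC(C)=O)[C@@]2(C)[C@@H](OC(=O)CC(C)C)C[C@@H](OC(C)=O)[C@]3(CO3)[C@@H]2[C@H](OC(C)=O)[C@]2(O)[C@@H](C)C(=O)O[C@H]2[C@H]1Cl`: 18000 nM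
- compound 3 `C=C1[C@H](OC(=O)CC(C)C)C[C@H](OC(C)=O)[C@@]2(C)[C@@H](OC(C)=O)[C@@H](OC(=O)CC(C)C)[C@@H](OC(C)=O)[C@]3(CO3)[C@@H]2[C@H](OC(C)=O)[C@]2(O)[C@@H](C)C(=O)O[C@H]2[C@H]1Cl`: 19100 nM

Compound 1 is known only through a limit, < 1500 nM, and not through a number. The unmeasured compound 4 `C=C1[C@H](OC(C)=O)C[C@H](OC(C)=O)[C@@]2(C)[C@@H](OC(C)=O)C[C@@H](OC(=O)CC(C)C)[C@]3(CO3)[C@@H]2[C@H](OC(C)=O)[C@]2(O)[C@@H](C)C(=O)O[C@H]2[C@H]1Cl` departs from it by one change: isopropyl in place of hydrogen on a saturated chain carbon bound to a carbonyl carbon. Cut one bond further out, this reads acetoxy to (isobutylcarbonyl)oxy.

One measured step is of the same kind: an at least 12-fold higher number from compound 1 to compound 2 (1.07 log units; beyond the scatter). Differing from compound 1 in more than one place, compound 3 gives 19100 nM, within the scatter of compound 2 at 18000 nM. A large step towards a higher number is therefore expected in this assay, of about the size seen for compound 2. Among the compounds with values here, the margin stays wide, with only one such single step measured. The estimated step is an at least 9.3-fold higher number from compound 1 to compound 4 (0.97 log units; beyond the scatter). The expected value for compound 4 is 14000 nM, within an estimated range from 5000 nM to 35000 nM.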

Compound 4, half-maximal inhibitory concentration: 16900 nM
Compound 4: middle estimate off by 1.2-fold (0.08 log units), on the low side; low and high end bracket the measured number.
By their numbers in this assay, from the lowest: compounds 4, 2 and 3 (each within the scatter of the next). At a limit, below all of these: compound 1.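

In this assay, exchanging a different acetoxy for (isobutylcarbonyl)oxy also gives a large step, an at least 11-fold higher number from compound 1 to compound 4 (1.05 log units; beyond the scatter), so the earlier large step, an at least 12-fold higher number from compound 1 to compound 2 (1.07 log units; beyond the scatter), is not confined to a single acetoxy of the shared core. The two single exchanges leave compound 2 at 18000 nM and compound 4 at 16900 nM, values within the scatter of each other. The value for compound 1 is a limit and not a number: the limit of < 1500 nM in this assay, at which 1 of the 4 values shown sits.

The compounds shown leave open whether a free hydroxyl, a benzoyl ester or an ester carrying a terminal amine at this place would stay close to compound 1. As far as these compounds go, the full size of the step also remains open, as does the outcome of this exchange made alone at the remaining acetoxy groups.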